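A few compounds are considered here, and "the series" means these few. Any claim that something is new, unique, unknown or untested is made for them only; others in the source may bear on it.

Among the measured compounds shown here, in a functional assay on IGROV-1 cells (Homo sapiens) for inhibition (on this read-out lower numbers stand for stronger inhibition and higher numbers for weaker inhibition), compound 1 (`CC(C)(C)c1cc(-c2ccc(/C=C/C(=O)O)cc2)ccc1O`) gives 30000 nM, at the high end of the numbers so far. Compound 3 (`O=C(O)/C=C/c1ccc(-c2ccc(O)c(-c3ccccc3)c2)cc1`), at 19000 nM, lies within the scatter of that value, while compound 2 (`O=C(O)/C=C/c1ccc(-c2ccc(O)c(CC3CCCCCCCCCCC3)c2)cc1`) reads clearly lower at 3570 nM. Compound 4 (`O=C(O)/C=C/c1ccc(-c2ccc(O)c(Cl)c2)cc1`) is still unmeasured. It carries chloro in place of tert-butyl on an aromatic carbon, ortho to a hydroxy group: chloro in place of tert-butyl on an aromatic carbon. For the measured compounds named here, the one measured step that bears on this is a 1.6-fold lower number from compound 1 to compound 3 (0.20 log units; within the scatter), a swap of phenyl for tert-butyl at the same carbon. No step beyond the scatter is therefore expected in this assay, and the estimated step is a 1.7-fold lower number from compound 1 to compound 4 (0.22 log units; within the scatter). Compound 4 is expected at 18000 nM, with an estimated range of 6000 nM to 40000 nM.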

Compound 4, half-maximal inhibitory concentration: 26000 nM
Estimate against measurement, compound 4: 1.4-fold (0.16 log units) below; the measured number falls inside the stated range.
By their numbers in this assay, from the lowest: compound 2; then compounds 3, 4 and 1 (each within the scatter of the next).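

Replacing tert-butyl with chloro gives a 1.2-fold lower number from compound 1 to compound 4 (0.06 log units; within the scatter) and replacing phenyl with chloro gives a 1.4-fold higher number from compound 3 to compound 4 (0.14 log units; within the scatter) in this assay so a single chlorine atom reads alike with both larger groups at this carbon. Chloro, tert-butyl and phenyl therefore cannot be told apart at this position on this read-out. Nothing measured here says why these groups read alike. Going by these compounds, whether an amine or a methoxy group at this carbon would shift the number stays open. So does the effect of a straight alkyl chain there.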